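The source may hold more compounds than are shown below. What is called first, only, known or untested is meant among the compounds shown, and "the series" means these compounds.

Compounds measured so far:
compound 1, `CNCc1cn(S(=O)(=O)c2ccco2)c(-c2cccnc2F)c1F`, 75%
compound 2, `CNCc1cn(S(=O)(=O)c2ccc(OC)cn2)c(-c2cccnc2F)c1F`, 95%
compound 3, `CNCc1cn(S(=O)(=O)c2cnccc2C)c(-c2cccnc2F)c1F`, 98%

In a functional assay on the whole organism (strain Jcl:Sprague-Dawley) for inhibition, with Rattus norvegicus as the target, with stated times of 3 min and 3 h, at a dose of 1 mg/kg by the intravenous route (a higher number here means more inhibition at the dose given (going by the name of the read-out), a lower number less inhibition), compound 3 gives the highest of the three numbers, but only compound 1 lies beyond the scatter from it; compound 2 sits within the scatter of compound 3 and no order between those two can be read. The two steps from the furan-2-yl sulfonyl of compound 1 to a pyridyl sulfonyl are a number 20 percentage points higher from compound 1 to compound 2 (beyond the scatter) and a number 23 percentage points higher from compound 1 to compound 3 (beyond the scatter), both modest and both beyond the scatter. Between the two pyridyl sulfonyls the step is a number 3 percentage points higher from compound 2 to compound 3 (within the scatter), within the scatter.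

Compound 4, `CNCc1cn(S(=O)(=O)c2ccc(C)nc2)c(-c2cccnc2F)c1F`, differs from compound 3 as follows: 6-methylpyridin-3-yl in place of 4-methylpyridin-3-yl on a sulfonyl sulfur. Among the measured compounds shown here, the step that bears most on this is the one between compound 2 and compound 3, where one pyridyl sulfonyl replaced another and the number did not move beyond the scatter. Compound 4 keeps a pyridyl on the sulfonyl sulfur, so no step beyond the scatter is expected in this assay; the expected step is a number 5 percentage points lower from compound 3 to compound 4 (within the scatter). The estimate for compound 4 in this assay is 93%, with a range from 80% to 100%, the upper end bounded by the highest number the read-out can give.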

Compound 4, a percentage reported as inhibition, in the whole organism at one dose (the size of the read-out at that dose, not a potency) in the Rattus norvegicus assay: 97%
Compound 4: the middle estimate sits 4 percentage points below what was measured; the range from low to high includes it.
By their numbers in the Rattus norvegicus assay, from the lowest: compound 1; then compounds 2, 4 and 3 (each within the scatter of the next).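

In the Rattus norvegicus assay, 6-methylpyridin-3-yl in place of 4-methylpyridin-3-yl on the sulfonyl sulfur gives a number 1 percentage points lower from compound 3 to compound 4 (within the scatter), and the comparison with 5-methoxypyridin-2-yl gives a number 2 percentage points higher from compound 2 to compound 4 (within the scatter), so this third pyridyl sulfonyl cannot be ordered against the other two. The separation from furan-2-yl holds, with a number 22 percentage points higher from compound 1 to compound 4 (beyond the scatter), and all three pyridyl sulfonyls in the series now lie beyond the scatter from compound 1, with none going against this. In a physicochemical assay for lipophilicity, read by HPLC, at pH 7.4 (a lower number here means a more polar compound, a higher number a more lipophilic compound), compound 3 gives 0.43 and compound 4 gives 0.62, which is a number 0.19 log units higher from compound 3 to compound 4 (within the scatter), so this exchange of one methylpyridyl for the other leaves both read-outs within the scatter.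

Still open, on these data alone, is whether a pyridyl carrying a carboxylic acid or a dimethylamino group, or a plain phenyl on the sulfonyl sulfur, would stay with these three in the Rattus norvegicus assay or fall towards compound 1. No evidence is at hand to explain the gap between the furan-2-yl and the pyridyl sulfonyls.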